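A few compounds are considered here, and "the series" means these few. Any claim that something is new, unique, unknown or untested is made for them only; others in the source may bear on it.

Compound 1 `COC(=O)/C(=C\c1ccc(O)cc1)Sc1ccnc2cc(Cl)ccc12` carries a free hydroxyl on its aromatic ring, and in a functional assay on Jurkat E6.1 cells (Homo sapiens) for cytotoxicity, read by MTT assay, with a stated time of 24 h (a lower number here means a stronger inhibitor, a higher number a weaker inhibitor), compound 1 gives 5180 nM. Compound 2 `COC(=O)/C(=C\c1ccc(OC(=O)c2ccc(OC)c(OC)c2)cc1)Sc1ccnc2cc(Cl)ccc12` has the (3,4-dimethoxyphenyl)carbonyl group placed on that oxygen in place of hydrogen, and in this assay compound 2 gives 8290 nM. That step, a 1.6-fold higher number from compound 1 to compound 2 (0.20 log units; within the scatter), lies within the scatter of repeated measurements, so the two compounds cannot be told apart on these numbers. Compound 3 `COC(=O)/C(=C\c1ccc(OC(=O)c2cc(OCc3ccccc3)c(OCc3ccccc3)c(OCc3ccccc3)c2)cc1)Sc1ccnc2cc(Cl)ccc12` bears a much larger acyl group with three benzyloxy substituents, and for compound 3 this assay reports only a limit, > 100000 nM, not a number (the limit of > 100000 nM in this assay, at which 1 of the 3 values shown sits). Among the two plain numbers, compound 2 holds the higher one, with compound 1 nearest to it.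

Compound 4 `COC(=O)/C(=C\c1ccc(OC(=O)c2ccc(OC)c(OC)c2OC)cc1)Sc1ccnc2cc(Cl)ccc12` is the not yet measured neighbour of compound 2. The change is methoxy in place of hydrogen on an aromatic carbon, so the acyl group changes from 3,4-dimethoxyphenyl to 2,3,4-trimethoxyphenyl. Among the measured compounds shown here, the only measured step that bears on this position, the step from compound 1 to compound 2, stayed within the scatter while adding the whole dimethoxyphenylcarbonyl group; one further methoxy is a far smaller change. For compound 4 the expected step in this assay is therefore a 1.1-fold higher number from compound 2 to compound 4 (0.06 log units; within the scatter), that is, no change beyond the scatter, and compound 4 is estimated at 9500 nM, between 4000 nM and 25000 nM.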

Compound 4, half-maximal inhibitory concentration: 2410 nM
Estimate against measurement, compound 4: 3.9-fold (0.60 log units) above, and the stated range ends above it.
By their numbers in this assay, from the lowest: compound 4; then compounds 1 and 2 (each within the scatter of the next). At a limit, above all of these: compound 3.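

In this assay, methoxy in place of hydrogen gives a 3.4-fold lower number from compound 2 to compound 4 (0.54 log units; beyond the scatter), the first step among these compounds that lies beyond the scatter. The earlier step, a 1.6-fold higher number from compound 1 to compound 2 (0.20 log units; within the scatter), could not be told apart from repeat-measurement noise even though it added a whole acyl group, so it showed nothing about how sensitive this part of the molecule is. The new result shows that the substitution pattern on that acyl ring can matter: one small methoxy, ortho to a large group and ortho to a methoxy group, moves the number by a real if modest amount, yet nothing measured here says why.

Going by these compounds, what an amine, a hydroxyl or a longer ethoxy chain would do on this same carbon remains open, so it cannot be said whether the lower number belongs to methoxy itself or to any group placed there. This single step on one acyl group also leaves open whether the same change would have a similar effect without the other two methoxy groups of the 2,3,4-trimethoxyphenyl ring.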